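The source may report more compounds than this note shows. Statements on the series, on what has been measured and on what is new or still open speak of the compounds shown alone.

Going by the values given here, in a functional assay (muscle tissue) with Cavia porcellus as the target (on this read-out higher numbers stand for an effect only at larger amounts of compound and lower numbers for an effect already at smaller amounts), compound 1 `COC(=O)C1=C(C)N=C(C)/C(=C(\O)OC)C1c1cccc(O)c1` gives 1000 nM, the highest of the three numbers so far. Compound 2 `COC(=O)C1=C(C)N=C(C)/C(=C(\O)OC)C1c1ccccc1F`, a 2-fluorophenyl analogue, gives 42.7 nM, and compound 3 `CCc1ccccc1C1C(C(=O)OC)=C(C)N=C(C)/C1=C(\O)OC`, a 2-ethylphenyl analogue, gives 6.46 nM. Compound 4 `COC(=O)C1=C(C)N=C(C)/C(=C(\O)OC)C1c1cccc(OC(C)=O)c1` keeps the core of compound 1 and changes one place: acetyl in place of hydrogen on an oxygen on an aromatic ring. In words, this is acetyl in place of hydrogen on an oxygen on an aromatic ring, or hydroxy to acetoxy.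

Among the compounds with values here, no measured step makes this exact change, so the evidence is indirect. Replacing 3-hydroxyphenyl with 2-fluorophenyl gave a 23-fold lower number from compound 1 to compound 2 (1.37 log units; beyond the scatter), and replacing it with 2-ethylphenyl gave a 150-fold lower number from compound 1 to compound 3 (2.19 log units; beyond the scatter). Both steps are large, and both remove the hydroxy group, as compound 4 also does. However, each swaps the whole substituted phenyl group, so they are only a loose guide. The step of a 6.6-fold lower number from compound 2 to compound 3 (0.82 log units; beyond the scatter) adds that the choice of group on the phenyl ring also moves the number, though only modestly. A lower number is therefore expected in this assay, but with less confidence than the measured steps might suggest. The estimated step is a 5.0-fold lower number from compound 1 to compound 4 (0.70 log units; beyond the scatter), short of the large steps measured. For compound 4, the expected value is 200 nM, with an estimated range of 40 nM to 1000 nM.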

Compound 4, half-maximal effective concentration: 6030 nM
Compound 4: middle estimate off by 30-fold (1.48 log units), on the low side; the measured number lies above the stated range.
By their numbers in this assay, from the lowest: compound 3; then compound 2; then compound 1; then compound 4.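

In this assay, putting acetyl in place of hydrogen on the oxygen of the hydroxy group gives a 6.0-fold higher number from compound 1 to compound 4 (0.78 log units; beyond the scatter), a step that is modest in size but runs in the opposite direction to the steps that led from compound 1 to compound 2 and compound 3. Those earlier steps swapped the whole substituted phenyl group, whereas this one changes only what sits on the oxygen, and it shows that the hydroxy group can be gone while the number still rises. The lower numbers of compound 2 and compound 3 therefore cannot be credited simply to the absence of the hydroxy group, and the data shown offer no measured explanation for the rise seen with acetoxy.

From the compounds shown here alone, what stays open is whether this rise belongs to the acetyl group in particular or would also appear with a plain methyl group or a longer acyl chain on the same oxygen. Going by these compounds, it is equally open how an amine in place of the hydroxy group would compare with compound 1 on this read-out.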